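Aromatic substitution series: from compound 2 to compound 3

A few compounds are considered here, and "the series" means these few. Any claim that something is new, unique, unknown or untested is made for them only; others in the source may bear on it.

Measured in an ADME assay on Raji cells (Homo sapiens) for cytotoxicity, read by CellTiter-Glo, with a stated time of 72 h; a higher number here means that more compound is needed for the effect, a lower number that less compound is needed:
- compound 1 `COc1ccc(/C2=C\C(=O)/C(C)=C\C3=C[C@H](C)C[C@@]34OC(=C(C)C4=O)CC2(C)C)cc1` gives 26000 nM
- compound 2 `CC1=C2CC(C)(C)/C(c3ccccc3)=C/C(=O)/C(C)=C\C3=C[C@H](C)C[C@]3(O2)C1=O` gives 26000 nM

Compound 2 stands level with compound 1 at the digits shown, so the series offers no ordering yet. The next compound is compound 3 `CC1=C2CC(C)(C)/C(c3ccc(C(F)(F)F)cc3)=C/C(=O)/C(C)=C\C3=C[C@H](C)C[C@]3(O2)C1=O`, and the change is trifluoromethyl in place of hydrogen on an aromatic carbon. Going by the values given here, only one measured step bears on it: no change at the digits printed from compound 1 to compound 2 (within the scatter), a change on an aromatic carbon that stays within the scatter. That single step involves methoxy, and trifluoromethyl has not been measured in this series, so the basis is thin. In this assay no shift beyond the scatter is therefore expected, and neither direction is favoured with any confidence. The expected outcome is a 1.1-fold lower number from compound 2 to compound 3 (0.03 log units; within the scatter). For compound 3 the estimate is 24000 nM, with an expected range from 11000 nM to 50000 nM.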

Compound 3, half-maximal effective concentration: 26000 nM
Compound 3: middle estimate off by 1.1-fold (0.03 log units), on the low side, within the range that was stated.
By their numbers in this assay, from the lowest: compounds 1, 2 and 3 (each within the scatter of the next).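

In this assay, trifluoromethyl on this aromatic carbon, para to a large group, gives no change at the digits printed from compound 2 to compound 3 (within the scatter) against hydrogen and no change at the digits printed from compound 1 to compound 3 (within the scatter) against methoxy . The earlier compounds shown here compared only hydrogen and methoxy here, whereas the three compounds now show no separation across three groups, and the step from phenyl to 4-(trifluoromethyl)phenyl adds four heavy atoms with no shift beyond the scatter. No supporting measurement is available to explain this flat reading.

As far as these compounds go, it remains open whether an amine or a carboxylic acid on this aromatic carbon would separate from these three compounds. Also open, from the compounds shown here alone, is whether any of these groups would give the same reading elsewhere on the six-membered aromatic ring, or with a change in the shared core.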